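Ring-opened amine in a succinamide series against gastric cancer cells

The source may hold more compounds than are shown below. What is called first, only, known or untested is meant among the compounds shown, and "the series" means these compounds.

The series rests on a shared core carrying two amide arms. Compound 1 `O=C(CC(CC(=O)NC1Cc2ccccc2C1)c1ccc(Cl)cc1)NCCN1CCCCC1` gives 89100 nM in a functional assay on MGC-803 cells (Homo sapiens) for inhibition; a higher number here means a weaker inhibitor, a lower number a stronger inhibitor. Compound 2 `CCN(C(=O)CC(CC(=O)NCCN1CCCCC1)c1ccc(Cl)cc1)C1Cc2ccccc2C1` gives 21200 nM in this assay, and the step of a 4.2-fold lower number from compound 1 to compound 2 (0.62 log units; beyond the scatter) is the only one beyond the scatter among the measured pairs. For compound 3 `Cc1ccc(C(CC(=O)NCCN2CCCCC2)CC(=O)NC2Cc3ccccc3C2)cc1` the assay reports only a limit, > 100000 nM; the step of an at least 1.1-fold higher number from compound 1 to compound 3 (0.05 log units; that floor lies within the scatter) rests on that limit (the limit of > 100000 nM in this assay, at which 1 of the 3 values shown sits). Compound 2 therefore stands lowest of the two numbers shown, with compound 1 as its nearest neighbour.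

Compound 4 `CCN(CC)CCNC(=O)CC(CC(=O)N(CC)C1Cc2ccccc2C1)c1ccc(Cl)cc1` differs from compound 2 by diethylamino in place of piperidin-1-yl on a saturated chain carbon, two bonds along the chain from an amide-type nitrogen. Neither measured step touches this basic amine end of the molecule: one concerns the ethyl on the amide-type nitrogen, the other the substituent on the aromatic ring. No measured comparison therefore bears on the change. The expectation is a step of a 1.2-fold higher number from compound 2 to compound 4 (0.07 log units; within the scatter) that stays within the scatter. Compound 4 is expected to give 25000 nM in this assay, within 8000 nM to 80000 nM.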

Compound 4, half-maximal inhibitory concentration: 44900 nM
Compound 4: the middle estimate sits 1.8-fold (0.25 log units) below what was measured; low and high end bracket the measured number.
By their numbers in this assay, from the lowest: compound 2; then compounds 4 and 1 (each within the scatter of the next). At a limit, above all of these: compound 3.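

Among the compounds shown here, this is the first measured change at this place, on a saturated chain carbon, two bonds along the chain from an amide-type nitrogen, and it shows that the group there can move the read-out in this assay. Diethylamino in place of piperidin-1-yl, an open group for a ring with one heavy atom fewer, gives a 2.1-fold higher number from compound 2 to compound 4 (0.33 log units; beyond the scatter), a modest step in favour of the ring. Nothing shown gives a reason for this step.

On these data alone, a single pair speaks for this place, so it stays open how a smaller amine such as dimethylamino, or another ring such as pyrrolidin-1-yl or morpholin-4-yl, would read there. As far as these compounds go, it also stays open whether the same step would appear with the amide hydrogen in place of the ethyl, or with methyl in place of chloro.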